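The source may hold more compounds than are shown below. What is called first, only, known or untested is meant among the compounds shown, and "the series" means these compounds.

Working notes on the series. Compound 1 `COc1ccc(S(=O)(=O)Oc2ccccc2/C=C(\C#N)C(=O)Nc2nnc(Cc3cccc4ccccc34)s2)cc1` gives 29% in an ADME assay on HEK-293T cells (Homo sapiens) for inhibition, read by CCK-8 assay, with a stated time of 48 h, tested at 20 uM; on this read-out higher numbers stand for more inhibition of growth at the one concentration tested and lower numbers for less inhibition of growth. Compound 2 `N#C/C(=C\c1ccccc1OS(=O)(=O)c1ccc([N+](=O)[O-])cc1)C(=O)Nc1nnc(Cc2cccc3ccccc23)s1` differs from compound 1 by nitro in place of methoxy on an aromatic carbon; in this assay compound 2 gives 25%, and the step is a number 4 percentage points lower from compound 1 to compound 2 (within the scatter). Compound 3 `COc1ccc(S(=O)(=O)Oc2ccccc2/C=C(\C#N)C(=O)Nc2nnc(Cc3ccc(C)cc3)s2)cc1` differs from compound 1 by 4-methylphenyl in place of naphthalen-1-yl on a saturated chain carbon bound to an aromatic carbon; in this assay compound 3 gives 28%, the step being a number 1 percentage points lower from compound 1 to compound 3 (within the scatter). All three values sit within the usual scatter of one another, so no order among them is claimed.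

Compound 4 `Cc1ccc(Cc2nnc(NC(=O)/C(C#N)=C/c3ccccc3OS(=O)(=O)c3ccc([N+](=O)[O-])cc3)s2)cc1` is not yet measured. It differs from compound 3 by nitro in place of methoxy on an aromatic carbon, the same change made from compound 1 to compound 2, in the same place. The two cores differ as described by 4-methylphenyl in place of naphthalen-1-yl on a saturated chain carbon bound to an aromatic carbon. Within the data shown here, the only instance of this change measured here is a number 4 percentage points lower from compound 1 to compound 2 (within the scatter). A step of about that size is expected, namely a number 3 percentage points lower from compound 3 to compound 4 (within the scatter), resting on one pair only. Compound 4 is therefore estimated at 25% in this assay, with a range from 15% to 35%.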

Compound 4, percent growth inhibition at one concentration: 9%
For compound 4 the middle estimate is 16 percentage points above the measured one, outside the stated range (below it).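

On the core of compound 3, nitro in place of methoxy gives a number 19 percentage points lower from compound 3 to compound 4 (beyond the scatter), and with nitro in place, 4-methylphenyl in place of naphthalen-1-yl gives a number 16 percentage points lower from compound 2 to compound 4 (beyond the scatter). The change from methoxy to nitro therefore does not carry from one core to the other as a step of fixed size in this assay: the same change on two cores in this assay, a number 4 percentage points lower (within the scatter) from compound 1 to compound 2 and a number 19 percentage points lower (beyond the scatter) from compound 3 to compound 4, 15 percentage points apart, beyond the scatter of two such steps. The change from naphthalen-1-yl to 4-methylphenyl behaves in the same way, so the two changes do not add independently in these four compounds, though this does not show why or whether the same holds on any other core: the same change on two cores in this assay, a number 1 percentage points lower (within the scatter) from compound 1 to compound 3 and a number 16 percentage points lower (beyond the scatter) from compound 2 to compound 4, 15 percentage points apart, beyond the scatter of two such steps.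

As far as these compounds go, it remains open whether the larger steps are tied to the specific pairing of nitro with 4-methylphenyl or would also appear with other groups. An amine or a carboxylic acid in place of nitro, or a longer chain in place of the methyl of 4-methylphenyl, would bear on that question.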